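Carrying a Fluoro-for-Methoxy Swap onto a Second Core

This account rests on a few compounds, and the source may have more. Where it says the series, first, only, none or still open, it means among the compounds named here.

In a functional assay on HL-60 cells (Homo sapiens) for cytotoxicity, read by MTT assay, with a stated time of 72 h (on this read-out higher numbers stand for weaker inhibition and lower numbers for stronger inhibition), compound 1 `COc1ccc(S(=O)(=O)c2nc3ccccc3nc2N2CCCC2)cc1` gives 16000 nM. Compound 2 `O=S(=O)(c1ccc(F)cc1)c1nc2ccccc2nc1N1CCCC1` differs from it by fluoro in place of methoxy on an aromatic carbon, and in this assay compound 2 gives 12800 nM; the step is a 1.3-fold lower number from compound 1 to compound 2 (0.10 log units; within the scatter). Compound 3 `COc1ccc(S(=O)(=O)c2nc3ccccc3nc2N2CCC(O)CC2)cc1` carries a different core, and the difference between the two cores is 4-hydroxypiperidin-1-yl in place of pyrrolidin-1-yl on an aromatic carbon. In this assay compound 3 gives 3230 nM, the lowest of the three numbers, reached by a 5.0-fold lower number from compound 1 to compound 3 (0.69 log units; beyond the scatter).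

Compound 4 `O=S(=O)(c1ccc(F)cc1)c1nc2ccccc2nc1N1CCC(O)CC1` has not been measured. It differs from compound 3 by fluoro in place of methoxy on an aromatic carbon. The place of this change is worded identically for the pair of compound 1 and compound 2 and for the pair of compound 3 and compound 4, so it is the same change, here carried onto the core of compound 3. On the core of compound 1 that change moved the number by a 1.3-fold lower number from compound 1 to compound 2 (0.10 log units; within the scatter), a step within the scatter. For the measured compounds named here, only this one earlier instance of the change is known, so it is the sole basis for any expectation.

The step from compound 3 to compound 4 is expected to be small, about a 1.3-fold lower number from compound 3 to compound 4 (0.11 log units; within the scatter). That expectation rests on the step of a 1.3-fold lower number from compound 1 to compound 2 (0.10 log units; within the scatter), which the same change made on the core of compound 1. Compound 4 is therefore estimated to give 2500 nM in this assay, with a likely range from 1000 nM to 6500 nM.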

Compound 4, half-maximal inhibitory concentration: 1450 nM
For compound 4 the middle estimate is 1.7-fold (0.24 log units) above the measured one; the measured number falls inside the stated range.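

In this assay, fluoro in place of methoxy, carried onto the second core, gives a 2.2-fold lower number from compound 3 to compound 4 (0.35 log units; beyond the scatter), and the two instances of this change agree as closely as such steps can be told apart: the same change on two cores in this assay, a 1.3-fold lower number (0.10 log units; within the scatter) from compound 1 to compound 2 and a 2.2-fold lower number (0.35 log units; beyond the scatter) from compound 3 to compound 4, 1.8-fold (0.25 log units) apart, within the scatter of two such steps. The other change in this set, 4-hydroxypiperidin-1-yl in place of pyrrolidin-1-yl, read here with fluoro on the aromatic ring, gives an 8.8-fold lower number from compound 2 to compound 4 (0.95 log units; beyond the scatter), and it too matches its counterpart read with methoxy: the same change on two cores in this assay, a 5.0-fold lower number (0.69 log units; beyond the scatter) from compound 1 to compound 3 and an 8.8-fold lower number (0.95 log units; beyond the scatter) from compound 2 to compound 4, 1.8-fold (0.25 log units) apart, within the scatter of two such steps. Within these four compounds, then, each change carries over from one core to the other with no measurable gap in size, but each rests on just two instances, so this does not show that either would carry onto any further core, and it gives no reason why either step has the size it has.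

The compounds shown leave open whether another group in the place para to a large group, such as chloro, trifluoromethyl or a nitrile, would follow the same course on both cores. They also leave open how much of the step to 4-hydroxypiperidin-1-yl belongs to the hydroxyl and how much to the larger ring, which a plain piperidin-1-yl or a morpholin-4-yl could help to separate.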